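This account rests on a few compounds, and the source may have more. Where it says the series, first, only, none or still open, it means among the compounds named here.

Working notes on the series. Of the compounds shown here, two of the shared core have been measured in a physicochemical assay for lipophilicity; a higher number here means a more lipophilic compound, a lower number a more polar compound. Compound 1 `CN1CCN(CCCS(=O)(=O)c2ccc3nc(NC(=O)NC(=O)c4cc(-n5cccc5)ccc4Cl)sc3c2)CC1` gives 2.6 in this assay. Compound 2 `CN1CCC(S(=O)(=O)c2ccc3nc(NC(=O)NC(=O)c4cc5c(cc4Cl)CCN5C)sc3c2)CC1`, which carries a different acyl part and a different amine part, gives 2.8 in this assay; the two numbers sit within the scatter of each other, so compound 1 and compound 2 cannot be told apart on this read-out. Among the compounds with values here, no single-change step between measured compounds is available, so nothing is known from about the effect of altering the five-membered ring.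

The next compound, compound 3 `CN1CCN(CCCS(=O)(=O)c2ccc3nc(NC(=O)NC(=O)c4cc(-n5cccn5)ccc4Cl)sc3c2)CC1`, keeps everything of compound 1 except one group: 1H-pyrazol-1-yl in place of 1H-pyrrol-1-yl on an aromatic carbon. One hetero atom and one hydrogen-bond acceptor are added to the five-membered ring, with no change in heavy-atom count and no charge. For this step the expectation is a modest move downward in this assay, of a size near the edge of the scatter, which is estimated as a number 0.40 log units lower from compound 1 to compound 3 (beyond the scatter). Compound 3 is therefore expected to give about 2.2 in this assay, within a range from 1.8 to 2.6.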

Compound 3, distribution coefficient: 2
The estimate for compound 3 lay 0.20 log units above the measured number; the measured number falls inside the stated range.
By their numbers in this assay, from the lowest: compound 3; then compounds 1 and 2 (each within the scatter of the next).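

Within the data shown here, the swap of 1H-pyrrol-1-yl for 1H-pyrazol-1-yl, on an aromatic carbon para to a chloro group and meta to a large group, gives the series its only single-change step: in this assay it yields a number 0.60 log units lower from compound 1 to compound 3 (beyond the scatter). The read-out at this position therefore responds to a change within the five-membered aromatic ring alone, in which one ring carbon gives way to nitrogen while the ring keeps its 5 heavy atoms, gains a hydrogen-bond acceptor, adds no hydrogen-bond donor and stays without net charge. No measurement is available that accounts for the size of this step.

On these data alone, it remains open whether a step of this size would recur with the different acyl part and amine part of compound 2, since this single pair shows the change on the side chain of compound 1 only. As far as these compounds go, it is equally open how this assay would respond to other groups at this position, such as 1H-imidazol-1-yl, a nitrile, a carboxylic acid or a morpholine, and so whether the 1H-pyrazol-1-yl result reflects a wider trend.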